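The source may hold more compounds than are shown below. What is called first, only, known or untested is meant among the compounds shown, and "the series" means these compounds.

Compound 1 `CNC(=O)[C@@]12C[C@@H]1[C@@H](n1cnc3c(NC4CC4c4cccc(Cl)c4)nc(C#Cc4ccccc4)nc31)[C@H](O)[C@@H]2O`: 6%
Compound 2 `CNC(=O)[C@@]12C[C@@H]1[C@@H](n1cnc3c(N[C@@H]4C[C@H]4c4ccc(F)c(F)c4)nc(C#Cc4ccccn4)nc31)[C@H](O)[C@@H]2O`: 19%

In an assay on CHO cells for displacement of a labelled ligand from adenosine receptor A1 (Homo sapiens), read by scintillation counting, with a stated time of 60 min, tested at 10 uM (on this read-out higher numbers stand for more inhibition at the one concentration tested (going by the name of the read-out) and lower numbers for less inhibition), compound 2 gives 19%, the higher of the two numbers, while compound 1 gives 6%, a gap beyond the scatter. Among the compounds with values here, compound 3 `CNC(=O)[C@@]12C[C@@H]1[C@@H](n1cnc3c(N[C@H]4C[C@@H]4c4ccc(F)c(F)c4)nc(C#Cc4ccccn4)nc31)[C@H](O)[C@@H]2O` remains unmeasured. the two compounds have the same atoms and bonds and differ only in configuration as drawn: 2 of 7 stereo elements differ; a stereocentre at a saturated ring carbon is drawn R in compound 2 and S in compound 3; a stereocentre at a saturated ring carbon is drawn S in compound 2 and R in compound 3 No measured pair shows a change of this kind, so its size in this assay is unknown; a modest fall, possibly no larger than the scatter, is expected. Compound 3 is expected to give 12%, within 0% to 30%. This means an expected step of a number 7 percentage points lower from compound 2 to compound 3 (within the scatter).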

Compound 3, a percentage reported as inhibition, at one concentration (the size of the read-out at that concentration, not a potency): 26%
Compound 3: middle estimate off by 14 percentage points, on the low side; low and high end bracket the measured number.
By their numbers in this assay, from the lowest: compound 1; then compounds 2 and 3 (each within the scatter of the next).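

Within the data shown here, this pair is the first to isolate configuration at the two saturated ring carbons, and in this assay swapping both stereocentres gives a number 7 percentage points higher from compound 2 to compound 3 (within the scatter). The comparison therefore rests on a single kind of difference: the fact that compounds 2 and 3 differ only in the configuration as drawn. At this single concentration, the read-out does not separate the two drawn configurations. The compounds shown leave open whether the configurations would remain this close with methoxy groups in place of the two fluorine atoms. They also leave open how the two configurations compare at other concentrations.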